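The source may report more compounds than this note shows. Statements on the series, on what has been measured and on what is new or still open speak of the compounds shown alone.

Compound 1 `Cc1ccccc1S(=O)(=O)Nc1ccc2oc(-c3ccccc3)nc2c1`: a limit, > 63000 nM.
Compound 2 `CS(=O)(=O)Nc1ccc2oc(-c3ccccc3)nc2c1`: a limit, > 63000 nM.

In an assay on isolated protein for inhibition of malate dehydrogenase, mitochondrial (Sus scrofa), with stated times of 45 min and 30 min (on this read-out higher numbers stand for weaker inhibition and lower numbers for stronger inhibition), compound 1 gives only a limit, > 63000 nM. Compound 2 likewise reaches only a limit, > 63000 nM. Among the compounds with values here, the step that the two limits leave unreadable from compound 1 to compound 2 therefore cannot be read, and the limit of > 63000 nM in this assay, at which 2 of the 2 values shown sit, is the only foothold the numbers give. Compound 3 `O=S(=O)(Nc1ccc2oc(-c3ccccc3)nc2c1)c1ccccc1C(F)(F)F` is the next variation: trifluoromethyl in place of methyl on an aromatic carbon. Within the data shown here, no measured step bears on this change, and with compound 1 itself at a limit no direction can be set. Compound 3 is expected to sit at or near the limit, around 100000 nM (range 30000 nM to 400000 nM). The expected step is a step that the limit leaves unreadable from compound 1 to compound 3.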

Compound 3, half-maximal inhibitory concentration: > 63000 nM
Compound 3: a limit, no number (the forecaster's own chance of this, stated with the estimate: 85%); the middle value lies beyond the limit too.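

Within the data shown here, compound 1 and compound 3 both give only a limit in this assay, so no step between them can be read. The compounds shown leave open whether any substituent change alters inhibition, with one foothold: the limit of > 63000 nM in this assay, at which 3 of the 3 values shown sit.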